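Notes on the side group: from compound 2 to compound 3

The source may report more compounds than this note shows. Statements on the series, on what has been measured and on what is new or still open speak of the compounds shown alone.

Of the compounds shown here, two on the shared core have been measured so far, compound 1 (`CCCCNc1nc2cc(-c3ccc(C)cc3)sc2c(=O)[nH]1`) and compound 2 (`CCCCCCC(C)Nc1nc2cc(-c3ccc(C)cc3)sc2c(=O)[nH]1`). In an ADME assay on HepG2 cells (Homo sapiens) for cytotoxicity, read by MTT assay, with a stated time of 72 h (on this read-out higher numbers stand for lower toxicity in this test and lower numbers for higher toxicity in this test), compound 1 gives 6000 nM and compound 2 gives 19400 nM, which is the higher of the two numbers. Compound 2 is therefore the less toxic of the pair in this test.

Compound 3 (`Cc1ccc(-c2cc3nc(NC(C)c4ccccc4)[nH]c(=O)c3s2)cc1`) is still unmeasured. The change from compound 2 is phenyl in place of hexyl on a saturated chain carbon bound to a nitrogen on an aromatic ring and a saturated chain carbon: phenyl in place of hexyl, which also reads as 1-methylheptyl to 1-phenylethyl.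

Among the measured compounds shown here, only one measured step bears on this change: a 3.2-fold higher number from compound 1 to compound 2 (0.51 log units; beyond the scatter), a modest move beyond the scatter for 1-methylheptyl in place of butyl. For the measured compounds named here, no compound measured so far carries a ring at this place, so the direction is only tentative. A modest move to a lower number is expected, part of the way back towards compound 1 at 6000 nM. The expected step is a 2.2-fold lower number from compound 2 to compound 3 (0.33 log units; beyond the scatter). Compound 3 is estimated at 9000 nM, with an expected range of 3500 nM to 22000 nM.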

Compound 3, half-maximal cytotoxic concentration: 9200 nM
Estimate against measurement, compound 3: 1.0-fold (0.01 log units) below; the measured number falls inside the stated range.
By their numbers in this assay, from the lowest: compounds 1 and 3 (each within the scatter of the next); then compound 2.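

In this assay, the first ring at this place gives a step beyond the scatter, a 2.1-fold lower number from compound 2 to compound 3 (0.32 log units; beyond the scatter), so hexyl and phenyl on this saturated chain carbon do not read alike, although the two groups match in their computed heavy-atom count. Measured against the butyl compound, the 1-phenylethyl group gives a 1.5-fold higher number from compound 1 to compound 3 (0.19 log units; within the scatter), which leaves compound 1 and compound 3 not separable in this test, and compound 2, with its 1-methylheptyl group, is the only one of the three set apart from both others. Nothing on hand gives a reason for either step.

The compounds shown do not tell whether the number of compound 2 follows from the length of its chain or from the methyl branch on the carbon bound to the nitrogen, and a straight octyl chain on that nitrogen would separate the two readings. They also leave open whether the aromatic character of the ring matters here or only the ring itself, a question that a cyclohexyl group in place of phenyl would address.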